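Swapping an amide for a sulfonamide on a shared core

The source may report more compounds than this note shows. Statements on the series, on what has been measured and on what is new or still open speak of the compounds shown alone.

Compound 3 `Cc1noc(C)c1C(=O)Nc1ncc(C(Oc2ccc3cc(Br)ccc3c2)c2ccc(Cl)cc2)s1` was tested in an ADME assay on HepG2 2.2.15 cells (Homo sapiens) for cytotoxicity (on this read-out lower numbers stand for higher toxicity in this test and higher numbers for lower toxicity in this test), where compound 3 gives "not toxic" (no number reported). Its close relatives share the same core. Compound 1 `O=C(Nc1ncc(C(Oc2ccc3cc(Br)ccc3c2)c2ccc(Cl)cc2)s1)C1CCCO1` gives "not toxic" (no number reported) in this assay. Compound 2 `O=C(Nc1ncc(C(Oc2ccc3cc(Br)ccc3c2)c2ccc(Cl)cc2)s1)c1ccc(F)cc1Br` reaches only a limit of this assay, giving > 50000 nM; this is the limit of > 50000 nM in this assay, at which 1 of the 3 values shown sits. So compound 3 stands among compounds that show no measurable toxicity, without a single number of its own. Compound 4 `O=S(=O)(Nc1ncc(C(Oc2ccc3cc(Br)ccc3c2)c2ccc(Cl)cc2)s1)c1cccs1` differs from compound 3 by (thiophen-2-yl)sulfonyl in place of (3,5-dimethyl-1,2-oxazol-4-yl)carbonyl on a nitrogen on an aromatic ring. Within the data shown here, no measured step between two compounds of this set exists, so no size can be drawn from the data; no shift beyond the scatter is expected here. Compound 4 is estimated at 50000 nM, expected to fall between 20000 nM and 200000 nM.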

Compound 4, half-maximal cytotoxic concentration: "not toxic" (no number reported)
Compound 4: no number reported, and the estimate cannot be compared.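

Among these compounds, compound 3 and compound 4 both read "not toxic" without a number in this assay, so no step between them can be read. The compounds shown leave open at what concentration, if any, this series harms the cells.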